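The source may hold more compounds than are shown below. What is called first, only, known or untested is meant among the compounds shown, and "the series" means these compounds.

Measured so far:
- compound 1 `C=CCSc1nncc2cnc(CCC)n12`: > 48000 nM
- compound 2 `CCCc1nc(Br)c2c(Br)nnc(O)n12`: 48000 nM
- compound 3 `C=CCSc1nncc2cnc(COC)n12`: 79000 nM

In a functional assay for inhibition, with Homo sapiens as the target (on this read-out higher numbers stand for weaker inhibition and lower numbers for stronger inhibition), compound 1 gives only a limit, > 48000 nM. In this assay compound 2 gives 48000 nM, and compound 3 gives 79000 nM; these two values lie within the scatter of each other. The difference between the core of compound 1 and the core of compound 2 is not broken down here.

The step from compound 1 to compound 3 is methoxy in place of ethyl on a saturated chain carbon bound to an aromatic carbon. Its size, a step that the limit leaves unreadable from compound 1 to compound 3, cannot be read because of the limit of > 48000 nM in this assay, at which 1 of the 3 values shown sits.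

Compound 4 `COCc1nc(Br)c2c(Br)nnc(O)n12` repeats the same change on compound 2: methoxy in place of ethyl on a saturated chain carbon bound to an aromatic carbon. With the measured step unreadable, the expectation for compound 4 rests on compound 2 at 48000 nM and on compound 3 at 79000 nM, and the step from compound 2 to compound 4 in this assay is estimated as a 1.4-fold higher number from compound 2 to compound 4 (0.13 log units; within the scatter). Compound 4 is expected to give about 65000 nM, estimated between 30000 nM and 140000 nM, with a fair chance that only a limit is reported.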

Compound 4, half-maximal inhibitory concentration: > 48000 nM
Compound 4: only a limit was reported (the forecaster's own chance of this, stated with the estimate: 45%); the middle value lies beyond the limit too.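

In this assay, carrying the change of ethyl to methoxy onto the core of compound 2 gives a number no lower from compound 2 to compound 4 (the limit leaves the size open), so this core shows no gain in inhibition from the change. Compound 4 gives only a limit, > 48000 nM. On these data alone, the sizes of the step on this core and of the same step on the core of compound 1 cannot be read, so it remains unknown whether the change has a similar size on both cores: the limit of > 48000 nM in this assay, at which 2 of the 4 values shown sit.

Still open, as far as these compounds go, is how far compound 4 lies from compound 2. Also open, from the compounds shown here alone, is whether an amine or a longer chain on the same saturated chain carbon would give a clearly lower number on either core.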